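Working notes: methoxy for bromo on the series

A few compounds are considered here, and "the series" means these few. Any claim that something is new, unique, unknown or untested is made for them only; others in the source may bear on it.

In a functional assay on NCI-H23 cells (Homo sapiens) for cytotoxicity, read by colorimetric assay (a higher number here means a weaker inhibitor, a lower number a stronger inhibitor), compound 2 `O=C(NO)c1ccc(CN2C(=O)/C(=C3\Nc4ccccc4\C3=N/O)c3cc(Br)ccc32)cc1` gives 7 nM and compound 1 `Cc1ccc2c(c1)/C(=C1/Nc3ccccc3/C1=N\O)C(=O)N2Cc1ccc(C(=O)NO)cc1` gives 10 nM, so the two stand level within the scatter. Compound 3 `COc1ccc2c(c1)/C(=C1/Nc3ccccc3/C1=N\O)C(=O)N2Cc1ccc(C(=O)NO)cc1` differs from compound 2 as follows: methoxy in place of bromo on an aromatic carbon. Going by the values given here, the one measured step at this place, bromo in place of methyl, is a 1.4-fold lower number from compound 1 to compound 2 (0.15 log units; within the scatter). Among the compounds with values here, no methoxy compound has been measured yet, so no step beyond the scatter is expected. The expected step is a 1.3-fold higher number from compound 2 to compound 3 (0.11 log units; within the scatter). Compound 3 is estimated at 9 nM, with an expected range of 4 nM to 22 nM.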

Compound 3, half-maximal inhibitory concentration: 90 nM
Estimate against measurement, compound 3: 10-fold (1.00 log units) below, outside the stated range (above it).
By their numbers in this assay, from the lowest: compounds 2 and 1 (each within the scatter of the next); then compound 3.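

Methyl and bromo had left this aromatic carbon looking indifferent, but in this assay methoxy gives a 13-fold higher number from compound 2 to compound 3 (1.11 log units; beyond the scatter) and a 9.0-fold higher number from compound 1 to compound 3 (0.95 log units; beyond the scatter). The position therefore does respond to the group it carries, and of the three groups compared only methoxy, the one with a hydrogen-bond acceptor, stands apart. Nothing at hand accounts for the shift.

Open, going by these compounds, is whether the oxygen or the two heavy atoms of methoxy go with the higher number. An ethyl or a hydroxy group at this carbon would separate those two readings.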